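Swapping an Acid Tail for a Hydroxycyclohexyl Ring

This account rests on a few compounds, and the source may have more. Where it says the series, first, only, none or still open, it means among the compounds named here.

Measured compounds:
Compound 1, `COc1cc(CNc2cc(Br)cc3[nH]ncc23)c([N+](=O)[O-])cc1OC`, in an assay for inhibition of Indoleamine 2,3-dioxygenase 1 (Homo sapiens), with stated times of 10 min and 60 min (a higher number here means a weaker inhibitor, a lower number a stronger inhibitor), gives 18500 nM.
Compound 2, `O=C(O)CNc1cccc(CNc2cc(C(F)(F)F)cc3[nH]ncc23)c1`, in this assay gives only a limit, > 100000 nM, not a number.

Compound 2 therefore sits at the limit of > 100000 nM in this assay, at which 1 of the 2 values shown sits, and nothing more precise about its potency is known from these data. Going by the values given here, compound 1 carries different groups on the shared core, so its value shows only that a measurable number is possible.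

Compound 3, `OC1CCCC(Nc2cccc(CNc3cc(C(F)(F)F)cc4[nH]ncc34)c2)C1`, differs from compound 2 in one place: 3-hydroxycyclohexyl in place of carboxymethyl on a nitrogen on an aromatic ring. Among the compounds with values here, no measured pair of compounds differing only in this way exists here, so the size of the step is open. Because compound 2 stands at the limit of > 100000 nM in this assay, at which 1 of the 2 values shown sits, any change that is detected can only appear as movement toward stronger inhibition. Compound 3 is expected to give about 50000 nM, within 10000 nM to 200000 nM. The expected step of an at least 2.0-fold lower number from compound 2 to compound 3 (0.30 log units; that floor lies within the scatter) points toward stronger inhibition, though a repeated limit remains quite possible.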

Compound 3, half-maximal inhibitory concentration: > 100000 nM
Compound 3 gave a limit, no number; the forecaster's own chance of this, stated with the estimate: 45%; middle value at least 2.0-fold (0.30 log units) away from the limit.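

No step can be read between compound 2 and compound 3, because each gives a limit rather than a number: the limit of > 100000 nM in this assay, at which 2 of the 3 values shown sit.

The compounds shown leave open whether 3-hydroxycyclohexyl in place of carboxymethyl changes inhibition at all, and in which direction.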